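The compounds below may be only part of what the source reports. "The series", "measured", "known", "first", "only" and "open" are said of these compounds alone.

In an ADME assay on Akata cells (Homo sapiens) for cytotoxicity, with a stated time of 7 days (on this read-out lower numbers stand for higher toxicity in this test and higher numbers for lower toxicity in this test), compound 3 `CC(C)CSc1nc(N)nc2c1ncn2/C=C1/CC1(CO)CO` gives only a limit, > 20000 nM. Compound 1 `CCCCCCCCOc1nc(N)nc2c1ncn2/C=C1/CC1(CO)CO` likewise yields no number in this assay but a limit, > 20000 nM. Compound 2 `Nc1nc(NC2CC2)c2ncn(/C=C3/CC3(CO)CO)c2n1` too stops at a limit there, > 20000 nM. All three therefore sit at the limit of > 20000 nM in this assay, at which 3 of the 3 values shown sit, and the steps a step that the two limits leave unreadable from compound 1 to compound 3, a step that the two limits leave unreadable from compound 2 to compound 3 and a step that the two limits leave unreadable from compound 1 to compound 2 cannot be sized. Compound 4 `Nc1nc(NCc2ccccc2)c2ncn(/C=C3/CC3(CO)CO)c2n1` differs from compound 3 by benzylamino in place of isobutylsulfanyl on an aromatic carbon. Among the measured compounds shown here, none of the measured steps reads the effect of such an exchange, and because every neighbour rests at the limit of > 20000 nM in this assay, at which 3 of the 3 values shown sit, no step beyond the scatter is expected in this assay. Compound 4 is thus estimated at 25000 nM, with a range from 12000 nM to 80000 nM. The expected step is a step that the limit leaves unreadable from compound 3 to compound 4, most likely reported again only as a limit.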

Compound 4, half-maximal cytotoxic concentration: > 24000 nM
Compound 4 gave a limit, no number; the forecaster's own chance of this, stated with the estimate: 85%; the middle value is on the limit's open side.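

Among the compounds shown here, compound 4, like compound 1, compound 2 and compound 3, gives only a limit in this assay, so no step among them can be read. The compounds shown leave open whether exchanging the group on the aromatic carbon changes cytotoxicity at all.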